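Bromo in Place of Chloro on the Shared Core

The source may hold more compounds than are shown below. What is called first, only, known or untested is meant among the compounds shown, and "the series" means these compounds.

Compound 2 `CCOC(=O)Cn1cnc2ncnc(Cl)c21` gives 21400 nM in a functional assay on G-361 cells (Homo sapiens) for antiproliferative activity, read by colorimetric assay and sulforhodamine B assay, with a stated time of 3 days (a higher number here means a weaker inhibitor, a lower number a stronger inhibitor), the highest of the two numbers at hand; its nearest neighbour, compound 1 `CCOC(=O)Cn1cnc2nc(Cl)nc(Cl)c21`, gives 5670 nM. Going by the values given here, the single measured step, a 3.8-fold higher number from compound 1 to compound 2 (0.58 log units; beyond the scatter), concerns hydrogen in place of chloro on an aromatic carbon and does not set one halogen against another. Compound 3 `CCOC(=O)Cn1cnc2ncnc(Br)c21` differs from compound 2 by bromo in place of chloro on an aromatic carbon. Among the compounds with values here, with no measured step bearing directly on this swap, in this assay the step is expected to stay within the scatter, a 1.2-fold lower number from compound 2 to compound 3 (0.08 log units; within the scatter). Compound 3 is therefore estimated at 18000 nM, within 7000 nM to 45000 nM.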

Compound 3, half-maximal inhibitory concentration: 18300 nM
Compound 3: the middle estimate sits 1.0-fold (0.01 log units) below what was measured; the range from low to high includes it.
By their numbers in this assay, from the lowest: compound 1; then compounds 3 and 2 (each within the scatter of the next).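

Bromo in place of chloro gives a 1.2-fold lower number from compound 2 to compound 3 (0.07 log units; within the scatter) in this assay and so leaves the two halogens indistinguishable at this aromatic carbon, whereas the earlier step set chloro only against hydrogen. A halogen at this place can therefore be exchanged for the next larger one without a change beyond the scatter, at least for this pair. Nothing at hand offers an explanation for this result. On these data alone, whether an amine, a methoxy group or a longer chain on this carbon would shift the number remains open. So does whether the same swap would behave alike on the core of compound 1.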